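Adding a Propylcarbamoyl Group to Compound 1

The source may report more compounds than this note shows. Statements on the series, on what has been measured and on what is new or still open speak of the compounds shown alone.

Measured in a functional assay on K562 cells (Homo sapiens) for antiproliferative activity, read by CCK-8 assay, with a stated time of 72 h; a higher number here means a weaker inhibitor of growth, a lower number a stronger inhibitor of growth:
- Compound 1 `CC[C@@H]1C(=O)N(C)c2cnc(-n3ccc4ccccc43)nc2N1C1CCCC1`: 6910 nM
- Compound 2 `CCCNC(=O)c1ccc2c(ccn2-c2ncc3c(n2)N(c2ccn(C)n2)C(CC)C(=O)N3C)c1`: 8270 nM

Compound 1 and compound 2 lie within the usual scatter of each other, so neither stands apart. Compound 3 `CCCNC(=O)c1ccc2c(ccn2-c2ncc3c(n2)N(C2CCCC2)[C@H](CC)C(=O)N3C)c1` changes compound 1 in one place: propylcarbamoyl in place of hydrogen on an aromatic carbon. For the measured compounds named here, no measured pair isolates this change in this assay. Compound 2 carries the same group and gives 8270 nM, which gives no sign of a large gain, so only a moderate fall in the number is expected. The expected step is a 2.3-fold lower number from compound 1 to compound 3 (0.36 log units; beyond the scatter). For compound 3 the estimate is 3000 nM, with an expected range of 500 nM to 9000 nM.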

Compound 3, concentration for 50% growth inhibition: 395 nM
Beside the measured number, compound 3's estimate is 7.6-fold (0.88 log units) above it; measured number below the stated range.
By their numbers in this assay, from the lowest: compound 3; then compounds 1 and 2 (each within the scatter of the next).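

In this assay, for the compounds shown here, the swap of hydrogen for propylcarbamoyl on this aromatic carbon gives a 17-fold lower number from compound 1 to compound 3 (1.24 log units; beyond the scatter) and so shows that this position on the core of compound 1 responds strongly to substitution, which no earlier pair could reveal. Nothing measured here explains this drop.
On these data alone, it remains open whether the amide hydrogen matters, and whether the propyl chain length does. A shorter methylcarbamoyl group, a longer butylcarbamoyl group or a carboxylic acid on this carbon could each give a different number.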